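The source may report more compounds than this note shows. Statements on the series, on what has been measured and on what is new or still open speak of the compounds shown alone.

The shared core appears in three measured members: compound 1 `Cc1cc(OC2CCCCC2)c(S(C)(=O)=O)cc1C(=O)N=C(N)N`, compound 2 `Cc1cc(Nc2cccc(Cl)c2)c(S(C)(=O)=O)cc1C(=O)N=C(N)N` and compound 3 `Cc1cc(Oc2cncc(Cl)c2)c(S(C)(=O)=O)cc1C(=O)N=C(N)N`. In a functional assay for inhibition of sodium/hydrogen exchanger (Oryctolagus cuniculus) (on this read-out higher numbers stand for weaker inhibition and lower numbers for stronger inhibition), compound 1 gives 37 nM, compound 2 gives 33 nM and compound 3 gives 14 nM. Compound 3 therefore stands lowest of the three numbers: its nearest neighbour is compound 2, with a step of a 2.4-fold lower number from compound 2 to compound 3 (0.37 log units; beyond the scatter), and its furthest is compound 1, with a step of a 2.6-fold lower number from compound 1 to compound 3 (0.42 log units; beyond the scatter); the step of a 1.1-fold lower number from compound 1 to compound 2 (0.05 log units; within the scatter) lies within the scatter.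

Compound 4 `Cc1cc(-n2ccc(=O)cc2)c(S(C)(=O)=O)cc1C(=O)N=C(N)N` has not yet been measured. It differs from compound 3 by a group of 7 heavy atoms (5 carbon, 1 nitrogen, 1 oxygen; one six-membered aromatic ring with 1 hetero atom) in place of a group of 8 heavy atoms (5 carbon, 1 nitrogen, 1 oxygen, 1 chlorine; one six-membered aromatic ring with 1 hetero atom), on an aromatic carbon. Among the compounds with values here, no measured step bears directly on this change. The two steps beyond the scatter, a 2.6-fold lower number from compound 1 to compound 3 (0.42 log units; beyond the scatter) and a 2.4-fold lower number from compound 2 to compound 3 (0.37 log units; beyond the scatter), each kept a ring bound through an oxygen or an amino group and ended at the (5-chloropyridin-3-yl)oxy group of compound 3, whereas the move to compound 4 gives up both that oxygen and the chlorine. The gain seen in compound 3 is thus not assured for compound 4, and a modest step back toward the numbers of compound 1 and compound 2 is expected, as a 2.9-fold higher number from compound 3 to compound 4 (0.46 log units; beyond the scatter). Compound 4 is accordingly estimated at 40 nM, with a range from 10 nM to 160 nM.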

Compound 4, half-maximal inhibitory concentration: 75 nM
Estimate against measurement, compound 4: 1.9-fold (0.27 log units) below; measured number inside the range.
By their numbers in this assay, from the lowest: compound 3; then compounds 2 and 1 (each within the scatter of the next); then compound 4.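

In this assay, compound 4 holds the highest number of the four, and each of its steps lies beyond the scatter: a 5.4-fold higher number from compound 3 to compound 4 (0.73 log units; beyond the scatter), a 2.3-fold higher number from compound 2 to compound 4 (0.36 log units; beyond the scatter) and a 2.0-fold higher number from compound 1 to compound 4 (0.31 log units; beyond the scatter). This shows that the aromatic carbon ortho to a methylsulfonyl group does not accept every six-membered aromatic ring with one hetero atom equally, since such a ring is present in both compound 3 and compound 4, yet the step between them is the largest of the three new ones. Nothing measured here accounts for this difference, so the result stands as an observation without an explanation.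

The change from compound 3 to compound 4 alters the attachment of the ring, removes the chlorine and brings in a double bond outside the ring all at once, so these compounds cannot show how much each alteration contributes; a pyridin-3-yloxy group without the chlorine would separate the oxygen link from the chlorine. Going by these compounds, it also remains open how this position would respond to a group outside this set of rings, such as a piperidin-1-yl amine or a carboxylic acid.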